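The source may report more compounds than this note shows. Statements on the series, on what has been measured and on what is new or still open speak of the compounds shown alone.

Series notes. In a functional assay on ileum for inhibition of histamine H1 receptor (Cavia porcellus) (on this read-out lower numbers stand for stronger inhibition and higher numbers for weaker inhibition), compound 1 `CCCOCCn1c(N2CCN(C)CC2)nc2ccccc21` gives 20 nM. Compound 2 `CCOCCn1c(N2CCNCC2)nc2ccccc21` gives 11 nM and compound 3 `CCCN1CCN(c2nc3ccccc3n2CCOCC)CC1` gives 16 nM in this assay; all three numbers lie within the scatter of one another, so compound 1 stands level with both. For the measured compounds named here, the one measured step, a 1.5-fold higher number from compound 2 to compound 3 (0.16 log units; within the scatter), concerns a different place in the molecule and does not bear on the change now considered. Compound 4 `CN1CCN(c2nc3ccccc3n2CCOc2ccccc2)CC1` differs from compound 1 by phenyl in place of propyl on an oxygen on a saturated carbon. Going by the values given here, no measured pair shows this exchange, so nothing here points to a step beyond the scatter in this assay in either direction. Compound 4 is thus expected to give about 20 nM in this assay, within a range of 6 nM to 65 nM. The expected step is no change at the digits printed from compound 1 to compound 4 (within the scatter).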

Compound 4, half-maximal inhibitory concentration: 6.9 nM
Compound 4: middle estimate off by 2.9-fold (0.46 log units), on the high side, within the range that was stated.
By their numbers in this assay, from the lowest: compounds 4, 2, 3 and 1 (each within the scatter of the next, the first and the last beyond it).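

For the compounds shown here, on an oxygen on a saturated carbon, this position accepts an aromatic ring: phenyl in place of propyl gives a 2.9-fold lower number from compound 1 to compound 4 (0.46 log units; beyond the scatter), the only step so far beyond the scatter. The exchange adds heavy atoms and a six-membered aromatic ring with no loss of inhibition in this assay. Nothing available bears on why the number falls.

Still open, from the compounds shown here alone, is whether the aromatic ring or simply the larger group matters. Cyclohexyl or benzyl on the same oxygen would separate the two, and a chlorophenyl would test whether the phenyl ring tolerates substitution.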